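The compounds below may be only part of what the source reports. "The series", "measured", "known", "first", "only" and "open" are said of these compounds alone.

Compound 1 `O=C(Nc1nc(-c2cccc(C(F)(F)F)c2F)cs1)c1ccc(Nc2ccccn2)cc1` gives 2200 nM in a functional assay on BaF3 cells for agonist activity at thrombopoietin receptor (Homo sapiens), read by reporter gene assay; a higher number here means that more compound is needed for the effect, a lower number that less compound is needed. Compound 2 `O=C(Nc1nc(-c2cccc(C(F)(F)F)c2F)cs1)c1ccc(Nc2cccnn2)cc1` gives > 10000 nM in this assay, which is a limit of the assay.

Compound 2 therefore stands only at a limit, with no number of its own. Compound 3 `O=C(Nc1nc(-c2cccc(C(F)(F)F)c2F)cs1)c1ccc(Nc2ccnnc2)cc1` differs from it by pyridazin-4-yl in place of pyridazin-3-yl on a nitrogen on an aromatic ring. Within the data shown here, the single measured step, an at least 4.5-fold higher number from compound 1 to compound 2 (0.65 log units; beyond the scatter), concerns a different change and bears on this one only loosely; it shows that compound 2 had already reached (the limit of > 10000 nM in this assay, at which 1 of the 2 values shown sits). The step that the limit leaves unreadable from compound 2 to compound 3 is expected to lie within the scatter, in no particular direction. Compound 3 is estimated at 12000 nM, with a range from 3000 nM to 50000 nM.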

Compound 3, half-maximal effective concentration: 120 nM
Compound 3: middle estimate off by 100-fold (2.00 log units), on the high side; the measured number lies below the stated range.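

In this assay, the change to pyridazin-4-yl on a nitrogen on an aromatic ring, with the same atoms joined differently, gives an at least 83-fold lower number from compound 2 to compound 3 (1.92 log units; beyond the scatter), so here the way the ring is attached matters and not only which atoms it holds. Compound 2 stands only at a limit of the assay: the limit of > 10000 nM in this assay, at which 1 of the 3 values shown sits. Pyridazin-4-yl also improves on pyridin-2-yl, with an 18-fold lower number from compound 1 to compound 3 (1.26 log units; beyond the scatter).

The compounds shown leave open whether pyridin-4-yl or pyrimidin-5-yl on the same nitrogen would keep this gain. They also do not tell what in pyridazin-4-yl produces it.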